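Vinyl to 2-chloropyridin-4-yl on the amide carbonyl

The source may hold more compounds than are shown below. What is called first, only, known or untested is meant among the compounds shown, and "the series" means these compounds.

Compound 1 `C=CC(=O)Nc1cccc(-c2nc3ccccc3s2)c1` carries a vinyl on the carbonyl carbon. In an ADME assay on Raji cells (Homo sapiens) for inhibition, with a stated time of 72 h (a lower number here means that less compound is needed, a higher number that more compound is needed for the effect), compound 1 gives only a limit, > 25000 nM. Compound 2 `O=C(Nc1cccc(-c2nc3ccccc3s2)c1)c1cccnc1Cl` carries a 2-chloropyridin-3-yl on that carbonyl carbon. In this assay compound 2 likewise gives only a limit, > 25000 nM. The step that the two limits leave unreadable from compound 1 to compound 2 cannot be sized, since both values sit at the limit of > 25000 nM in this assay, at which 2 of the 2 values shown sit. Compound 3 `O=C(Nc1cccc(-c2nc3ccccc3s2)c1)c1ccnc(Cl)c1` alters compound 1 by 2-chloropyridin-4-yl in place of vinyl on a carbonyl carbon. Within the data shown here, the single comparable step gives no readable size, so no change beyond the scatter is expected. Compound 3 is estimated at 30000 nM, ranging from 5000 nM to 100000 nM, a step that the limit leaves unreadable from compound 1 to compound 3, most probably again a limit.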

Compound 3, half-maximal effective concentration: > 25000 nM
Compound 3: no number, only a limit (the forecaster's own chance of this, stated with the estimate: 85%); the middle value lies beyond the limit too.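

Compound 1, compound 2 and compound 3 all remain limits in this assay, so no step among them can be read: the limit of > 25000 nM in this assay, at which 3 of the 3 values shown sit.

Still open, from the compounds shown here alone, is how vinyl, 2-chloropyridin-3-yl and 2-chloropyridin-4-yl on the carbonyl carbon rank in this assay, and whether any group there gives a measurable value.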